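Swapping an Acid for an Amide on the Side Chain

The compounds below may be only part of what the source reports. "The series", "measured", "known", "first", "only" and "open" are said of these compounds alone.

Compound 1 `NC(=O)C[C@H](NC(=O)CN(c1nc(Cl)nc2[nH]cnc12)C1CC1)C(=O)O` and compound 2 `O=C(O)C[C@H](NC(=O)CN(c1nc(Cl)nc2[nH]cnc12)C1CC1)C(=O)O` share one core. Among the measured compounds shown here, in a functional assay on the whole organism (Tail, strain ICR) with Mus musculus as the target, in the tail flick test, with a stated time of 150 min, at a dose of 25 umol/kg by the oral route (a lower number here means a weaker effect, a higher number a stronger effect of the compound at the dose given), compound 1 gives 7.51% and compound 2 gives 11.6%; the single step measured, a number 4.1 percentage points higher from compound 1 to compound 2 (within the scatter), shows that these two values lie within the scatter of each other, so compound 2 stands level with compound 1. Compound 3 `NC(=O)CC[C@H](NC(=O)CN(c1nc(Cl)nc2[nH]cnc12)C1CC1)C(=O)O` differs from compound 2 by carbamoylmethyl in place of carboxy on a saturated chain carbon, two bonds along the chain from an amide-type nitrogen and a carbonyl carbon. For the measured compounds named here, the one measured step bears on this change only loosely, and it was small, so no shift beyond the scatter is expected: a number 2.1 percentage points lower from compound 2 to compound 3 (within the scatter). Compound 3 is therefore estimated at 9.5%, in the range 2% to 19%.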

Compound 3, a percentage reported as activity, at one dose (the size of the read-out at that dose, not a potency): 11.4%
The estimate for compound 3 lay 1.9 percentage points below the measured number, and the stated range covers the measured number.
By their numbers in this assay, from the lowest: compounds 1, 3 and 2 (each within the scatter of the next).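

Putting carbamoylmethyl in place of carboxy on this saturated chain carbon leaves the result in this assay level (a number 0.2 percentage points lower from compound 2 to compound 3 (within the scatter)). Putting it in place of carbamoyl does the same (a number 3.9 percentage points higher from compound 1 to compound 3 (within the scatter)), so among these three compounds, neither the end group nor the added chain carbon separates the numbers at this dose. No measurement available here offers an explanation for this flat result.

From the compounds shown here alone, it remains open whether a different group on this carbon, such as an amine or a phenyl ring, would move the number beyond the scatter.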